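The source may hold more compounds than are shown below. What is called first, only, known or untested is meant among the compounds shown, and "the series" means these compounds.

Measured so far in a functional assay on A549 cells (Homo sapiens) for antiproliferative activity, read by MTT assay, with a stated time of 72 h; a higher number here means a weaker inhibitor, a lower number a stronger inhibitor: compound 1 `CNC(=O)c1cc(Oc2ccc(NC(=O)c3cc4cccnc4n(-c4ccccc4)c3=O)cc2)ccn1` gives 200 nM; compound 2 `CNC(=O)c1cc(Oc2ccc(NC(=O)c3cc4cccnc4n(-c4ccccc4F)c3=O)cc2)ccn1` gives 610 nM.

Among the measured compounds shown here, compound 2 holds the higher of the two numbers in this assay; the single measured step is a 3.1-fold higher number from compound 1 to compound 2 (0.48 log units; beyond the scatter), a modest rise beyond the scatter. Compound 3 `CNC(=O)c1cc(Oc2ccc(NC(=O)c3cc4cccnc4n(-c4ccc(Cl)cc4)c3=O)cc2)ccn1` differs from compound 2 by 4-chlorophenyl in place of 2-fluorophenyl on an aromatic nitrogen. For the measured compounds named here, that step bears on the change only in part: compound 3 carries no fluoro, and the chloro has no measured counterpart. A partial return toward compound 1 is therefore expected, a 1.5-fold lower number from compound 2 to compound 3 (0.18 log units; within the scatter), with wide uncertainty. Compound 3 is estimated at 400 nM (range 150 nM to 1000 nM).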

Compound 3, half-maximal inhibitory concentration: 370 nM
Beside the measured number, compound 3's estimate is 1.1-fold (0.03 log units) above it; the range from low to high includes it.
By their numbers in this assay, from the lowest: compounds 1, 3 and 2 (each within the scatter of the next, the first and the last beyond it).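

On the aromatic nitrogen, 4-chlorophenyl in place of 2-fluorophenyl gives a 1.6-fold lower number from compound 2 to compound 3 (0.22 log units; within the scatter) in this assay, so these two halogenated compounds are not separated. Chloro in place of hydrogen gives a 1.9-fold higher number from compound 1 to compound 3 (0.27 log units; within the scatter) and thus, unlike the fluoro step, stays within the scatter. No measured evidence accounts for either step.

The 2-fluorophenyl and 4-chlorophenyl groups differ in both halogen and place, so the effects of the two cannot be separated here. From the compounds shown here alone, how a methoxy group, an amine or a carboxylic acid on this phenyl ring would read remains open.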